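Lengthening the alkenyl chain of compound 3

The source may hold more compounds than are shown below. What is called first, only, known or untested is meant among the compounds shown, and "the series" means these compounds.

In a functional assay on T98G cells (Homo sapiens) for inhibition, read by colorimetric assay and MTT assay, with a stated time of 72 h (a higher number here means a weaker inhibitor, a lower number a stronger inhibitor), compound 3 `C=CCCOc1ncc(-c2ccccc2OC)n1C` gives 39000 nM, within the scatter of compound 2 `CCCCCCOc1ncc(-c2ccccc2OC)n1C` at 58000 nM. Compound 1 `C=CCCCCOc1ccccc1-c1cnc(OCCCCC=C)n1C` stands clearly lower at 4000 nM, which leaves compound 3 second highest of the three. Compound 4 `C=CCCCCOc1ncc(-c2ccccc2OC)n1C` differs from compound 3 by but-3-en-1-yl in place of vinyl on a saturated chain carbon, two bonds along the chain from an oxygen on an aromatic ring. Among the compounds with values here, the only measured step at this place, vinyl in place of butyl, is a 1.5-fold lower number from compound 2 to compound 3 (0.17 log units; within the scatter), and it stayed within the scatter. No clear change is therefore expected in this assay, in either direction. The estimated step is a 1.0-fold higher number from compound 3 to compound 4 (0.01 log units; within the scatter). Compound 4 is expected near 40000 nM, with an estimated range of 18000 nM to 85000 nM.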

Compound 4, half-maximal inhibitory concentration: 5000 nM
Compound 4: middle estimate off by 8.0-fold (0.90 log units), on the high side, and the stated range ends above it.
By their numbers in this assay, from the lowest: compounds 1 and 4 (each within the scatter of the next); then compounds 3 and 2 (each within the scatter of the next).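

In this assay, lengthening the but-3-en-1-yl chain to hex-5-en-1-yl pays off (a 7.8-fold lower number from compound 3 to compound 4 (0.89 log units; beyond the scatter)), and so does the double bond at the end of the six-carbon chain (a 12-fold lower number from compound 2 to compound 4 (1.06 log units; beyond the scatter)), so the gain needs both the longer chain and the double bond. The second long chain of compound 1 brings no clear further change, since replacing it with methoxy stays within the scatter (a 1.3-fold higher number from compound 1 to compound 4 (0.10 log units; within the scatter)). No measurement shown explains why this chain works better. Still open, as far as these compounds go, is whether a longer alkenyl chain, such as oct-7-en-1-yl, or an alkyne or amine at the chain end, would do as well.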